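Swapping one chlorine for fluorine in a leukotriene inhibitor

The compounds below may be only part of what the source reports. "The series", "measured", "known", "first", "only" and "open" are said of these compounds alone.

Of the compounds shown here, three of one series have been measured in an assay on isolated protein for inhibition of leukotriene C4 synthase (Homo sapiens), read by LC-MS, with stated times of 45 min and 20 min; a higher number here means a weaker inhibitor, a lower number a stronger inhibitor. Compound 1 `COc1cc(N(CC2CC2)c2ccc(Cl)c(Cl)c2)cnc1C(=O)[C@H]1C[C@@H]1C(=O)O` gives 27.7 nM. Compound 2 `CCCN(c1cnc(C(=O)[C@H]2C[C@@H]2C(=O)O)c(OC)c1)c1ccc(F)c2ccccc12` gives 7.09 nM, and compound 3 `COc1cc(N(CC2CC2)c2cc(C(F)(F)F)ccc2F)cnc1C(=O)[C@H]1C[C@@H]1C(=O)O` gives 14 nM. Of these three numbers compound 1 has the highest; the value of compound 3 lies close enough to fall within the usual scatter of such measurements, while the gap to compound 2 lies beyond it.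

Compound 4 `COc1cc(N(CC2CC2)c2ccc(F)c(Cl)c2)cnc1C(=O)[C@H]1C[C@@H]1C(=O)O` has not yet been measured. It differs from compound 1 in a single place: fluoro in place of chloro on an aromatic carbon. Within the data shown here, no pair of measured compounds shows this same exchange, so its effect can only be guessed from the wider picture, in which compound 3, carrying a differently substituted ring in the same position, stays within scatter of compound 1. The expected change is a 1.4-fold higher number from compound 1 to compound 4 (0.16 log units; within the scatter), a small drift toward a higher number that may well remain within scatter. Compound 4 is therefore estimated at 40 nM, with a range from 15 nM to 110 nM.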

Compound 4, half-maximal inhibitory concentration: 42.3 nM
Beside the measured number, compound 4's estimate is 1.1-fold (0.02 log units) below it, within the range that was stated.
By their numbers in this assay, from the lowest: compounds 2, 3, 1 and 4 (each within the scatter of the next, the first and the last beyond it).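

Compound 1 and compound 4 differ only at this one ring position, so they give the series its first direct reading of a single change. In this assay, going from 3,4-dichlorophenyl to 3-chloro-4-fluorophenyl gives a 1.5-fold higher number from compound 1 to compound 4 (0.18 log units; within the scatter) and so leaves the two compounds indistinguishable, which means that at this carbon, ortho to a chloro group and para to a large group, fluoro serves as well as chloro. No available measurement accounts for this similarity.

The compounds shown cover only these two halogens at this position, so it remains open whether a methyl group, a nitrile or a bromo group would give a similar number. Nor do they show what happens with plain hydrogen there, with neither halogen on that carbon.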